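Extending the Ether: Methyl to Isopropyl on Compound 2

The source may report more compounds than this note shows. Statements on the series, on what has been measured and on what is new or still open speak of the compounds shown alone.

Of the compounds shown here, three have been measured in a physicochemical assay for lipophilicity; a higher number here means a more lipophilic compound, a lower number a more polar compound. Compound 1 `CCOC[C@H](Oc1ncnc2c1cnn2-c1ncccc1Cl)C(=O)Nc1ccc(Cl)cn1` gives 3, compound 2 `COC[C@H](Oc1ncnc2c1cnn2-c1ccccc1Cl)C(=O)Nc1ccc(C)cn1` gives 3.4, and compound 3 `COC[C@H](Oc1ncnc2c1cnn2-c1ncccc1Cl)C(=O)Nc1cnc(C)cn1` gives 1.4. Compound 2 stands highest of the three: its nearest neighbour is compound 1, whose number lies lower beyond the scatter, and compound 3 lies furthest below it, also beyond the scatter. Compound 4 `Cc1ccc(NC(=O)[C@H](COC(C)C)Oc2ncnc3c2cnn3-c2ccccc2Cl)nc1` has not yet been measured. It differs from compound 2 in one place: isopropyl in place of methyl on an oxygen on a saturated carbon. Among the compounds with values here, no measured pair shows this change, so no direct step is available. In this assay the step from compound 2 to compound 4 is expected to run upward, beyond the scatter and of moderate size, namely a number 0.90 log units higher from compound 2 to compound 4 (beyond the scatter). Compound 4 is estimated at 4.3, with a range from 3.8 to 4.8.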

Compound 4, distribution coefficient: 3.9
Compound 4: the middle estimate sits 0.40 log units above what was measured, and the stated range covers the measured number.
By their numbers in this assay, from the lowest: compound 3; then compound 1; then compound 2; then compound 4.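

In this assay, isopropyl in place of methyl on an oxygen on a saturated carbon gives a number 0.50 log units higher from compound 2 to compound 4 (beyond the scatter). Within the data shown here, this is the first direct reading at this position, as the earlier compounds offered no pair differing in one place, and it shows that the number here responds to the ether group alone. Nothing among the data shown accounts for the size of this step.

Going by these compounds, whether a butyl chain or an amine at the end of this ether would move the number further remains open. So does whether the step would hold on the other compounds, which differ elsewhere.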